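A few compounds are considered here, and "the series" means these few. Any claim that something is new, unique, unknown or untested is made for them only; others in the source may bear on it.

Compound 3 `CS/C(=N\C(=O)c1cccs1)NC(=O)c1cccs1` and compound 2 `O=C(/N=C(/NC(=O)c1cccs1)[Se]Cc1ccccc1)c1cccs1` share a core and differ in one place: a group of 8 heavy atoms (7 carbon, 1 selenium; one six-membered aromatic ring of carbon only) in place of a group of 2 heavy atoms (1 carbon, 1 sulfur; no ring), on a carbon with a double bond to nitrogen. In a functional assay on HepG2 cells (Homo sapiens) for cytotoxicity, read by MTT assay, with a stated time of 72 h (on this read-out lower numbers stand for stronger inhibition of growth and higher numbers for weaker inhibition of growth), compound 3 gives a value that is only a limit of the assay, > 100000 nM. In this assay compound 2 gives 58100 nM. The step measured for this change is an at least 1.7-fold lower number from compound 3 to compound 2 (0.23 log units; that floor lies within the scatter), and its floor rests on (the limit of > 100000 nM in this assay, at which 2 of the 3 values shown sit).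

Compound 1 `CS/C(=N\C(=O)c1ccco1)NC(=O)c1ccco1` has a different core from compound 3; the difference between the two cores is not broken down here. In this assay compound 1 also gives only a limit of the assay, > 100000 nM.

Compound 4 `O=C(/N=C(/NC(=O)c1ccco1)[Se]Cc1ccccc1)c1ccco1` is not yet measured. It stands to compound 1 as compound 2 stands to compound 3, and the change is the same: a group of 8 heavy atoms (7 carbon, 1 selenium; one six-membered aromatic ring of carbon only) in place of a group of 2 heavy atoms (1 carbon, 1 sulfur; no ring), on a carbon with a double bond to nitrogen. The place of the change is described in the same words for both pairs, so the change is taken as the same one.

Because the measured step of an at least 1.7-fold lower number from compound 3 to compound 2 (0.23 log units; that floor lies within the scatter) is only a floor set by a limit, the step from compound 1 to compound 4 is expected to be of similar size, an at least 1.5-fold lower number from compound 1 to compound 4 (0.18 log units; that floor lies within the scatter). For compound 4 the value in this assay is estimated at 65000 nM, expected to fall between 30000 nM and 140000 nM, with a real chance that only a limit is reported, as for compound 1.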

Compound 4, concentration for total growth inhibition: 39500 nM
Beside the measured number, compound 4's estimate is 1.6-fold (0.22 log units) above it; the range from low to high includes it.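

On the core of compound 1, putting the selenium-bearing group with its six-membered aromatic ring in place of methylsulfanyl, on a carbon with a double bond to nitrogen, gives an at least 2.5-fold lower number from compound 1 to compound 4 (0.40 log units; beyond the scatter) in this assay. Set beside the same change on the core of compound 3, the number falls on both cores, but only the floor on the core of compound 1 lies beyond the scatter, so the two pairs agree in direction without showing that the change carries over with the same size: the same change on two cores in this assay, an at least 1.7-fold lower number (0.23 log units; that floor lies within the scatter) from compound 3 to compound 2 and an at least 2.5-fold lower number (0.40 log units; beyond the scatter) from compound 1 to compound 4; the limit leaves it open whether they differ. Neither step has a true size, and the pairs cannot show whether one core responds more strongly than the other, since each step starts from a limit rather than from a number: the limit of > 100000 nM in this assay, at which 2 of the 4 values shown sit.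

The selenium atom and the aromatic ring enter together in both pairs, so the compounds shown leave open which of the two goes with the lower numbers. A benzylsulfanyl group would hold the ring while removing the selenium, a methylselanyl group would hold the selenium without the ring, and either would test this on both cores.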